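Removing One Aromatic Methyl from Aromatase Inhibitors

This account rests on a few compounds, and the source may have more. Where it says the series, first, only, none or still open, it means among the compounds named here.

Compound 1 `Cc1cc(S(=O)(=O)N2CCCC(Cn3ccnc3)C2)ccc1F` is one of three sulfonamides tested in an assay on isolated protein for inhibition of Aromatase (Homo sapiens), read by fluorescence (a lower number here means a stronger inhibitor, a higher number a weaker inhibitor), where compound 1 gives 24 nM. In this assay compound 2 `O=S(=O)(c1ccc(F)cc1)N1CCCC(Cn2ccnc2)C1` gives 51 nM. The structural change between them is hydrogen in place of methyl on an aromatic carbon, and it made the step of a 2.1-fold higher number from compound 1 to compound 2 (0.33 log units; beyond the scatter). In this assay compound 3 `COc1c(C)cc(S(=O)(=O)N2CCCC(Cn3ccnc3)C2)c(C)c1C` gives 45 nM; how its core differs from the core of compound 1 is not broken down here. Compound 4 `COc1ccc(S(=O)(=O)N2CCCC(Cn3ccnc3)C2)c(C)c1C` has not yet been measured; it differs from compound 3 by hydrogen in place of methyl on an aromatic carbon. This is the same kind of change as that from compound 1 to compound 2, but the surroundings differ: in compound 1 the carbon is ortho to a fluoro group, whereas in compound 3 it is ortho to a methoxy group, meta to a methyl group and para to a methyl group, both being meta to a large group. Resting on the modest size of that earlier step, compound 4 is expected to show the step of a 1.9-fold higher number from compound 3 to compound 4 (0.28 log units; within the scatter). Compound 4 is therefore estimated at 85 nM, with a likely range from 35 nM to 200 nM.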

Compound 4, half-maximal inhibitory concentration: 59 nM
Compound 4: the middle estimate sits 1.4-fold (0.16 log units) above what was measured, within the range that was stated.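

On the second core, putting hydrogen in place of the aromatic methyl gave a 1.3-fold higher number from compound 3 to compound 4 (0.12 log units; within the scatter) in this assay, so here the effect of the change cannot be told apart from ordinary measurement scatter. Set beside the earlier step, this one does not differ measurably: the same change on two cores in this assay, a 2.1-fold higher number (0.33 log units; beyond the scatter) from compound 1 to compound 2 and a 1.3-fold higher number (0.12 log units; within the scatter) from compound 3 to compound 4, 1.6-fold (0.21 log units) apart, within the scatter of two such steps. The two results are compatible with the change carrying over between these cores, but two pairs cannot establish a rule for the series or explain what the surroundings of the methyl contribute.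

The compounds shown carry only hydrogen or methyl at this place, so the outcome with an ethyl group, a chlorine atom or an amine there remains open. Also open, as far as these compounds go, is whether the step would hold on cores with other groups around that aromatic carbon.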